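Taking one chloro off compound 2

The source may report more compounds than this note shows. Statements on the series, on what has been measured and on what is new or still open speak of the compounds shown alone.

In a functional assay on MCF7 cells (Homo sapiens) for antiproliferative activity, read by MTT assay, with a stated time of 48 h (on this read-out higher numbers stand for weaker inhibition and lower numbers for stronger inhibition), compound 2 (`O=C(/C=C/c1cc(Cl)cc(Cl)c1Oc1c([N+](=O)[O-])cc(C(F)(F)F)cc1[N+](=O)[O-])c1ccc(Cl)cc1`) holds the higher of the two numbers at 4.54 ug/mL. Compound 1 (`Cc1ccc(C(=O)/C=C/c2cccc(Cl)c2Oc2c([N+](=O)[O-])cc(C(F)(F)F)cc2[N+](=O)[O-])cc1`) stands at 0.03 ug/mL. The gap between these two compounds lies beyond the scatter. Compound 3 (`O=C(/C=C/c1cccc(Cl)c1Oc1c([N+](=O)[O-])cc(C(F)(F)F)cc1[N+](=O)[O-])c1ccc(Cl)cc1`) departs from compound 2 by hydrogen in place of chloro on an aromatic carbon. The data show no earlier instance of this exact change. Compound 1 at 0.03 ug/mL shows that far lower numbers occur among these compounds, so a lower number is expected. The expected move is a 10-fold lower number from compound 2 to compound 3 (1.00 log units; beyond the scatter), toward stronger inhibition and beyond the scatter. Compound 3 is expected at 0.45 ug/mL, with an estimated range of 0.06 ug/mL to 3.5 ug/mL.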

Compound 3, half-maximal inhibitory concentration: 3.21 ug/mL
The estimate for compound 3 lay 7.1-fold (0.85 log units) below the measured number; measured number inside the range.
By their numbers in this assay, from the lowest: compound 1; then compounds 3 and 2 (each within the scatter of the next).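

In this assay, hydrogen in place of chloro on this aromatic carbon, meta to the 2-((4-chlorophenyl)carbonyl)ethenyl group, gives a 1.4-fold lower number from compound 2 to compound 3 (0.15 log units; within the scatter), so this chloro has no effect that can be told from the scatter. The one-place change of chloro in place of methyl on an aromatic carbon, by contrast, gives a 110-fold higher number from compound 1 to compound 3 (2.03 log units; beyond the scatter), a large step. Nothing given here accounts for either step.

From the compounds shown here alone, it remains open whether an amine or a methoxy group at the position of the lost chloro would read differently from chloro and hydrogen. Going by these compounds, it also remains open whether an ethyl group in place of the methyl of compound 1 would keep its low number.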